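Methyl in place of chloro on compound 1

The source may hold more compounds than are shown below. What is called first, only, known or untested is meant among the compounds shown, and "the series" means these compounds.

Compound 1 `CSc1cc(C)nc(Cl)c1NC(=O)N(Cc1ccc(Oc2ccc(F)cc2)cc1)C1CCCCCC1` gives 0.17 mg/kg
Compound 2 `Cc1cc(S(C)(=O)=O)c(NC(=O)N(Cc2ccc(Oc3ccc(F)cc3)cc2)C2CCCCCC2)c(S(C)(=O)=O)n1` gives 0.63 mg/kg

In a functional assay on the whole organism with Rattus norvegicus as the target (a higher number here means that more compound is needed for the effect, a lower number that less compound is needed), compound 1 holds the lower of the two numbers, and compound 2 at 0.63 mg/kg lies above it by more than the usual scatter. Compound 3 `CSc1cc(C)nc(C)c1NC(=O)N(Cc1ccc(Oc2ccc(F)cc2)cc1)C1CCCCCC1` keeps the core of compound 1 and changes a single group, with methyl in place of chloro on an aromatic carbon next to the ring nitrogen. For the measured compounds named here, compound 2 differs from compound 1 in more than one place, so no measured pair shows this exchange alone. Only a small move toward a higher number is expected, an estimated 1.5-fold higher number from compound 1 to compound 3 (0.17 log units; within the scatter) that would stay within the scatter. For compound 3 the expected value is 0.25 mg/kg and the estimated range runs from 0.08 mg/kg to 0.8 mg/kg around it.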

Compound 3, dose for half-maximal effect: < 1 mg/kg
Compound 3: a limit, no number (the forecaster's own chance of this, stated with the estimate: 5%); the middle value does not contradict the limit.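

In this assay, for the compounds shown here, compound 3 gives < 1 mg/kg, which is a limit and not a number, so no step between compound 1 and compound 3 can be read. From the compounds shown here alone, whether methyl in place of chloro on an aromatic carbon shifts the number beyond the usual scatter, and in which direction, stays open.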